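Pyridin-3-yl to pyridin-4-yl on the amine nitrogen

The source may report more compounds than this note shows. Statements on the series, on what has been measured and on what is new or still open speak of the compounds shown alone.

Compound 1 (`CC(=O)NC[C@H]1CN(c2ccc(OC[C@@H](O)CNc3ccccc3)c(F)c2)C(=O)O1`) reads 124000 nM in a physicochemical assay for solubility, read by HPLC (on this read-out lower numbers stand for lower solubility and higher numbers for higher solubility), and has the lowest of the three measured numbers. Compound 2 (`CC(=O)NC[C@H]1CN(c2ccc(OC[C@@H](O)CNc3ccccn3)c(F)c2)C(=O)O1`) reads 22200000 nM on this assay and has the highest. Compound 3 (`CC(=O)NC[C@H]1CN(c2ccc(OC[C@H](O)CNc3cccnc3)c(F)c2)C(=O)O1`) reads 10100000 nM on this assay and stands second highest, below compound 2 and well above compound 1.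

Compound 4 (`CC(=O)NC[C@H]1CN(c2ccc(OC[C@H](O)CNc3ccncc3)c(F)c2)C(=O)O1`) differs from compound 3 in one group, with pyridin-4-yl in place of pyridin-3-yl on an amine nitrogen. The two have the same atoms, joined differently.

Among the compounds with values here, three measured steps bear on this change. The two that start from the phenyl compound were large (a 180-fold higher number from compound 1 to compound 2 (2.25 log units; beyond the scatter)) and (an 81-fold higher number from compound 1 to compound 3 (1.91 log units; beyond the scatter)), but neither resembles the change at hand, which keeps a pyridine on the amine. Within the data shown here, the closest precedent is the step between the two pyridine compounds, which was modest (a 2.2-fold lower number from compound 2 to compound 3 (0.34 log units; beyond the scatter)). Among the measured compounds shown here, no measurement yet shows the pyridin-4-yl group, so the direction remains open. On this assay, a small step is therefore expected, no larger than that modest one and perhaps within the scatter. The expected step is small (a 1.2-fold higher number from compound 3 to compound 4 (0.07 log units; within the scatter)). The estimate for compound 4 is 12000000 nM with an expected range of 4000000 nM to 35000000 nM (an estimate only).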

Compound 4, solubility: 24600000 nM
For compound 4 the middle estimate is 2.1-fold (0.31 log units) below the measured one, within the range that was stated.
By their numbers in this assay, from the lowest: compound 1; then compound 3; then compounds 2 and 4 (each within the scatter of the next).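

In this assay, moving the ring nitrogen from pyridin-3-yl to pyridin-4-yl on the amine nitrogen proved to be a measurable change, with a 2.4-fold higher number from compound 3 to compound 4 (0.39 log units; beyond the scatter), so two groups with the same atoms and the same counts are told apart at this position. The pyridin-4-yl and pyridin-2-yl compounds, however, cannot be separated on this read-out, with a 1.1-fold higher number from compound 2 to compound 4 (0.04 log units; within the scatter), which leaves compound 3 as the only one of the three pyridine compounds set apart from the others, and by a modest step. All three pyridine compounds stand far from the phenyl compound, and the pyridin-4-yl compound does so with a 200-fold higher number from compound 1 to compound 4 (2.30 log units; beyond the scatter), so the choice among these pyridine groups moves the number far less than the step away from phenyl does.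

No measurement at hand gives a reason for these differences. The compounds shown also leave open whether this ordering would hold with a methyl group on the amine nitrogen, or with a carboxylic acid or a further amine on the pyridine ring.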